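The compounds below may be only part of what the source reports. "The series", "measured", "known", "first", "only" and "open" are said of these compounds alone.

Going by the values given here, in a physicochemical assay for solubility, read by nephelometry, measured as kinetic solubility (on this read-out higher numbers stand for higher solubility and lower numbers for lower solubility), two compounds that share one core have numbers so far. Compound 1 `CCC/N=C1\S/C(=C\c2ccc(C(=O)O)cc2)C(=O)N1c1ccccc1C` gives 163000 nM, and compound 2 `CCC/N=C1\S/C(=C\c2ccc(C(=O)OCCO)cc2)C(=O)N1c1ccccc1C` gives 110000 nM. Among the compounds with values here, the single measured step is a 1.5-fold lower number from compound 1 to compound 2 (0.17 log units; within the scatter), and it came from putting 2-hydroxyethyl in place of hydrogen. On these numbers, compound 2 therefore cannot be told apart from compound 1.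

Compound 3 `CCC/N=C1\S/C(=C\c2ccc(C(=O)NCCO)cc2)C(=O)N1c1ccccc1C` keeps the shared core and alters one link in the side chain: (2-hydroxyethyl)amino in place of 2-hydroxyethoxy on a carbonyl carbon. Put simply, (2-hydroxyethyl)amino stands in place of 2-hydroxyethoxy on a carbonyl carbon, so the chain keeps its name but is attached differently. Within the data shown here, no measured step makes this exact exchange, which leaves the evidence indirect. Among the measured compounds shown here, the only guide is a 1.5-fold lower number from compound 1 to compound 2 (0.17 log units; within the scatter), a change in the same part of the molecule that stayed within the scatter. No shift beyond the scatter is therefore expected in this assay, and no direction can be favoured with confidence. The expected change is a 1.1-fold higher number from compound 2 to compound 3 (0.04 log units; within the scatter). For compound 3 the estimated value is 120000 nM, with an expected range from 60000 nM to 200000 nM.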

Compound 3, solubility: > 250000 nM
Compound 3 was reported as a limit; the forecaster's own chance of this, stated with the estimate: 10%; at least 2.0-fold (0.31 log units) between middle value and limit.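

Joined to the carbonyl carbon through a different link, the same two-carbon chain now gives a clear change in this assay: with (2-hydroxyethyl)amino in place of 2-hydroxyethoxy there is an at least 2.2-fold higher number from compound 2 to compound 3 (0.35 log units; beyond the scatter), so the link matters here even though the earlier step stayed within the scatter. With (2-hydroxyethyl)amino in place of hydroxy on that carbonyl carbon there is an at least 1.5-fold higher number from compound 1 to compound 3 (0.18 log units; that floor lies within the scatter), so this floor does not separate the two compounds. Compound 3 is reported only as a limit and not as a number, so both steps are floors, because the read-out stops there: the limit of > 250000 nM in this assay, at which 1 of the 3 values shown sits.

The compounds shown leave open how large the true step from the ester-linked chain to the amide-linked chain is. They also leave open whether the change carries over to other groups on a carbonyl carbon, such as (3-hydroxypropyl)amino with its longer chain, ethylamino without the end hydroxy, or dimethylamino without the amide hydrogen.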